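The source may report more compounds than this note shows. Statements on the series, on what has been measured and on what is new or still open speak of the compounds shown alone.

Three compounds that share one core and carry a 4-(1H-imidazol-1-yl)butoxy group have been measured in a functional assay on K-562R cells (Homo sapiens) for cytotoxicity, read by XTT assay, with a stated time of 24 h; a higher number here means a weaker inhibitor, a lower number a stronger inhibitor. There, compound 1 (`COc1ccc(C(=O)Nc2ccc(C)c(Nc3nccc(-c4cccnc4)n3)c2)cc1OCCCCn1ccnc1`) gives 18700 nM, compound 2 (`Cc1ccc(NC(=O)c2ccc(OCCCCn3ccnc3)c(Br)c2)cc1Nc1nccc(-c2cccnc2)n1`) gives 31800 nM and compound 3 (`Cc1ccc(NC(=O)c2ccc(I)cc2OCCCCn2ccnc2)cc1Nc1nccc(-c2cccnc2)n1`) gives 51800 nM. Compound 2 holds the middle of these three numbers, and its gaps to compound 1 and to compound 3 both lie within the scatter.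

Compound 4 (`COc1cc(C(=O)Nc2ccc(C)c(Nc3nccc(-c4cccnc4)n3)c2)ccc1OCCCCn1ccnc1`) differs from compound 2 in one place: methoxy in place of bromo on an aromatic carbon. This puts methoxy in place of bromo on an aromatic carbon, ortho to the 4-(1H-imidazol-1-yl)butoxy group. Going by the values given here, no measured pair isolates this change, so the data give no direct step to go by. The nearest guide is compound 1, which also carries a methoxy group and gives 18700 nM. On that basis, no change beyond the scatter is expected, and the estimated 1.2-fold lower number from compound 2 to compound 4 (0.09 log units; within the scatter) is small. The estimate for compound 4 is 26000 nM, with an expected range from 13000 nM to 52000 nM.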

Compound 4, half-maximal inhibitory concentration: 27100 nM
Estimate against measurement, compound 4: 1.0-fold (0.02 log units) below; low and high end bracket the measured number.
By their numbers in this assay, from the lowest: compounds 1, 4, 2 and 3 (each within the scatter of the next, the first and the last beyond it).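

Going by these compounds alone, this is the first measured pair that isolates the exchange on this aromatic carbon, ortho to a 4-(1H-imidazol-1-yl)butoxy group: in this assay methoxy in place of bromo gives a 1.2-fold lower number from compound 2 to compound 4 (0.07 log units; within the scatter) and so does not separate the two groups at this position. The exchange adds one heavy atom and one hydrogen-bond acceptor, yet the read-out stays within the scatter. No available measurement accounts for this result.

As far as these compounds go, whether an amine, a carboxylic acid or a plain hydrogen on this same carbon would shift the number beyond the scatter remains open. From the compounds shown here alone, it is also open whether methoxy and bromo would remain indistinguishable here if a longer chain replaced the 4-(1H-imidazol-1-yl)butoxy group.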